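The compounds below may be only part of what the source reports. "The series", "measured", "known", "first", "only" and "open" are said of these compounds alone.

Measured so far in a functional assay with Alpha-1B adrenergic receptor (Homo sapiens) as the target, read by calcium flux; a lower number here means a smaller maximal response, a higher number a larger maximal response:
compound 1, `CC(C)n1nccc1-c1ccccc1NCC1=NCCN1`: 0%
compound 2, `CCn1ncnc1-c1ccccc1NCC1=NCCN1`: 94%
compound 3, `c1ccc(-c2nc[nH]n2)c(NCC2=NCCN2)c1`: 100%

Compound 3 and compound 2 give numbers that sit within the scatter of each other, at the full-response end of the series; compound 1 stands far beyond the scatter, with no measurable response at all. Among the measured compounds shown here, no pair of these three differs in a single place, so no single-site step is available as a guide.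

Compound 4, `Cn1cccc1-c1ccccc1NCC1=NCCN1`, not yet measured, differs from compound 3 in one place: 1-methyl-1H-pyrrol-2-yl in place of 1H-1,2,4-triazol-3-yl on an aromatic carbon. Two ring nitrogens and the ring hydrogen-bond donor are lost while a methyl on nitrogen enters.

A step of moderate size downward in this assay is expected, a number 50 percentage points lower from compound 3 to compound 4 (beyond the scatter), with wide uncertainty given the spread from compound 1 to compound 3. Compound 4 is estimated at 50%, within 5% to 100%.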

Compound 4, largest response reached (reported as maximal response), in percent of the reference or control that the assay uses: 0%
Beside the measured number, compound 4's estimate is 50 percentage points above it; measured number below the stated range.
By their numbers in this assay, from the lowest: compounds 1 and 4 (each within the scatter of the next); then compounds 2 and 3 (each within the scatter of the next).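

In this assay, among the compounds shown here, the swap of 1H-1,2,4-triazol-3-yl for 1-methyl-1H-pyrrol-2-yl on this aromatic carbon gives a number 100 percentage points lower from compound 3 to compound 4 (beyond the scatter) as the first single-site step. The maximal response thus depends strongly on the five-membered ring at this position, and one change here is enough to remove it. Nothing available accounts for this loss.

This change alters the ring nitrogens, the ring hydrogen-bond donor and the methyl on nitrogen together, and the compounds shown do not separate them. A 1H-pyrrol-2-yl at this position would part the methyl from the ring atoms.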